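Cytotoxicity notes on triazole substituent variation, toward compound 4

The source may report more compounds than this note shows. Statements on the series, on what has been measured and on what is new or still open speak of the compounds shown alone.

Measured so far:
compound 1 `CCCCCCc1cn(C(c2ccccc2)c2cc3cc(Br)ccc3nc2OC)nn1`
compound 2 `CCCCc1cn(C(c2ccccc2)c2cc3cc(Br)ccc3nc2OC)nn1`
compound 3 `COc1nc2ccc(Br)cc2cc1C(c1ccccc1)n1cc(-c2ccc(OC(F)(F)F)cc2)nn1`

In an ADME assay on HEK293 cells (Homo sapiens) for cytotoxicity, read by sulforhodamine B assay, with a stated time of 48 h, tested at 10 uM (on this read-out higher numbers stand for more inhibition at the one concentration tested (going by the name of the read-out) and lower numbers for less inhibition), compound 1 gives -3.17%, compound 2 gives -3.47% and compound 3 gives 5.8%. Compound 3 holds the highest of the three numbers, but its separation from compound 1 and from compound 2 stays within the scatter, so no order among them can be claimed.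

Compound 4 `COc1nc2ccc(Br)cc2cc1C(c1ccccc1)n1cc(C2CC2)nn1` differs from compound 3 by cyclopropyl in place of 4-(trifluoromethoxy)phenyl on an aromatic carbon. Going by the values given here, the steps that bear on this are a number 9 percentage points higher from compound 1 to compound 3 (within the scatter) and a number 9.3 percentage points higher from compound 2 to compound 3 (within the scatter); both swap a chain for the aryl group at the same ring carbon and neither leaves the scatter, and a number 0.3 percentage points lower from compound 1 to compound 2 (within the scatter) shows chain length likewise mattering little. In this assay no step beyond the scatter is therefore expected for compound 4.

Compound 4 is estimated at 1%, with a range of -8% to 10%. That estimate corresponds to an expected step of a number 4.8 percentage points lower from compound 3 to compound 4 (within the scatter).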

Compound 4, a percentage reported as inhibition, at one concentration (the size of the read-out at that concentration, not a potency): 8.22%
For compound 4 the middle estimate is 7.2 percentage points below the measured one; the measured number falls inside the stated range.
By their numbers in this assay, from the lowest: compounds 2, 1, 3 and 4 (each within the scatter of the next, the first and the last beyond it).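

In this assay, going by these compounds alone, cyclopropyl on this aromatic carbon gives the only steps beyond the scatter so far, with a number 11.7 percentage points higher from compound 2 to compound 4 (beyond the scatter) and a number 11.4 percentage points higher from compound 1 to compound 4 (beyond the scatter) against the two chains. Against the aryl group the step is a number 2.4 percentage points higher from compound 3 to compound 4 (within the scatter) and the read-out does not separate cyclopropyl from 4-(trifluoromethoxy)phenyl, despite 3 against 11 heavy atoms. No evidence is available on what lies behind these steps.

Open, going by these compounds, is whether an amine or a carboxylic acid on this carbon would move the read-out further. Also open, on these data alone, is whether a shorter chain such as ethyl behaves like the butyl and hexyl chains or like cyclopropyl.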